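A few compounds are considered here, and "the series" means these few. Any claim that something is new, unique, unknown or untested is made for them only; others in the source may bear on it.

Three compounds have been measured in a functional assay on CHO cells for antagonist activity at transient receptor potential cation channel subfamily V member 1 (Rattus norvegicus); on this read-out higher numbers stand for weaker inhibition and lower numbers for stronger inhibition:

Compound 1 `Cc1ccc(CNC(=O)C(C)c2ccc(NS(C)(=O)=O)c(F)c2)cc1` gives 930 nM.
Compound 2 `CC(C)c1ccc(CNC(=O)C(C)c2ccc(NS(C)(=O)=O)c(F)c2)cc1` gives 144 nM.
Compound 3 `CC(C(=O)NCc1ccc(C2CC2)cc1)c1ccc(NS(C)(=O)=O)c(F)c1` gives 55.5 nM.

Compound 3 stands lowest of the three numbers in this assay; the nearest is compound 2, the furthest compound 1. The measured steps all concern the same position: a 6.5-fold lower number from compound 1 to compound 2 (0.81 log units; beyond the scatter), a 17-fold lower number from compound 1 to compound 3 (1.22 log units; beyond the scatter) and a 2.6-fold lower number from compound 2 to compound 3 (0.41 log units; beyond the scatter). Each replacement of the methyl by a larger group at this aromatic carbon gave a lower number, and the cyclopropyl gave the lowest of all.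

Compound 4 `CC(C(=O)NCc1ccc(C2C=CCC2)cc1)c1ccc(NS(C)(=O)=O)c(F)c1` continues this series with a single change: cyclopent-2-en-1-yl in place of cyclopropyl on an aromatic carbon. Among the compounds with values here, no measured step covers this particular ring, so the expectation rests only on the direction seen in the three steps, which all point the same way, with the caution that compound 3 is already the lowest number and the gap from compound 2 to compound 3 was only modest. Compound 4 is therefore expected to give a number in this assay close to that of compound 3, with a small downward lean, estimated as 45 nM within 15 nM to 150 nM. This estimate means a step of a 1.2-fold lower number from compound 3 to compound 4 (0.09 log units; within the scatter), which may well lie within the scatter.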

Compound 4, inhibition constant: 15 nM
Compound 4: the middle estimate sits 3.0-fold (0.48 log units) above what was measured; measured number inside the range.
By their numbers in this assay, from the lowest: compound 4; then compound 3; then compound 2; then compound 1.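

In this assay the downward run at this position does not end with the cyclopropyl: cyclopent-2-en-1-yl gives a 3.7-fold lower number from compound 3 to compound 4 (0.57 log units; beyond the scatter) and thus shows that a five-membered non-aromatic ring of carbon only is accepted on this aromatic carbon, para to a large group, and takes the number lower still. Set against the two open-chain groups, the same ring gives a 9.6-fold lower number from compound 2 to compound 4 (0.98 log units; beyond the scatter) and a 62-fold lower number from compound 1 to compound 4 (1.79 log units; beyond the scatter) and so widens the span seen at this position, leaving compound 4 with the lowest number of the four, with its steps to all three others printed as beyond the scatter. No accompanying measurement bears on why this ring gives the lowest number.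

The compounds shown leave open what the ring double bond contributes, which a saturated cyclopentyl group at this place would address, and whether the downward run continues to a cyclohexyl or a phenyl ring. On these data alone, all four groups hold carbon only, so the outcome with a ring containing nitrogen or oxygen, such as a pyrrolidine or a morpholine, also remains open.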